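Aryl swap on the pyrazole nitrogen: compound 4 expected

A few compounds are considered here, and "the series" means these few. Any claim that something is new, unique, unknown or untested is made for them only; others in the source may bear on it.

Compound 1 `CC(C(=O)NCc1cc(C(F)(F)F)nn1-c1ccc(Cl)cc1)c1ccc2c(c1)CCC2` gives 45 nM in an assay on CHO-K1 cells for antagonist activity at transient receptor potential cation channel subfamily V member 1 (Homo sapiens), read by FLIPR; a lower number here means a stronger inhibitor, a higher number a weaker inhibitor. Compound 2 `CC(C(=O)NCc1cc(C(F)(F)F)nn1-c1ccc(C(F)(F)F)cc1)c1ccc2c(c1)CCC2` gives 51.3 nM. Compound 3 `CC(C(=O)NCc1cc(C(F)(F)F)nn1-c1ccc(F)c(F)c1)c1ccc2c(c1)CCC2` gives 30.5 nM.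

Compound 3 stands at the low end of these three numbers, yet with a 1.5-fold lower number from compound 1 to compound 3 (0.17 log units; within the scatter) and a 1.7-fold lower number from compound 2 to compound 3 (0.23 log units; within the scatter) neither gap reaches beyond the scatter. Compound 4 `Cc1ccc(-n2nc(C(F)(F)F)cc2CNC(=O)C(C)c2ccc3c(c2)CCC3)cc1C` differs from compound 3 only in the group on the aromatic nitrogen: 3,4-dimethylphenyl in place of 3,4-difluorophenyl on an aromatic nitrogen. The two steps that bear on this change are the aryl swaps from compound 1 and from compound 2 to compound 3, and both stayed within the scatter. No step beyond the scatter is therefore expected for compound 4 in this assay, a 1.3-fold higher number from compound 3 to compound 4 (0.12 log units; within the scatter). Compound 4 is estimated at 40 nM, within a range from 15 nM to 120 nM.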

Compound 4, inhibition constant: 11.3 nM
Compound 4: middle estimate off by 3.5-fold (0.55 log units), on the high side; the measured number lies below the stated range.
By their numbers in this assay, from the lowest: compound 4; then compounds 3, 1 and 2 (each within the scatter of the next).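

On the aromatic nitrogen, swaps among 4-chlorophenyl, 4-(trifluoromethyl)phenyl and 3,4-difluorophenyl had all stayed within the scatter, but 3,4-dimethylphenyl moves the number beyond it in this assay, with a 2.7-fold lower number from compound 3 to compound 4 (0.43 log units; beyond the scatter) and a 4.0-fold lower number from compound 1 to compound 4 (0.60 log units; beyond the scatter) and a 4.5-fold lower number from compound 2 to compound 4 (0.66 log units; beyond the scatter). This position therefore responds to the choice of aryl group, at least for this one entering group. Nothing available here explains this difference.

The compounds shown leave open whether a single methyl on the phenyl ring would suffice, and whether methoxy or an amine could replace the two methyl groups.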